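A Dimethylamino Group on the Benzyl of Compound 1

A few compounds are considered here, and "the series" means these few. Any claim that something is new, unique, unknown or untested is made for them only; others in the source may bear on it.

Compound 1 `COC(=O)N[C@H](C(=O)NN(CCC[C@@](O)(Cc1ccccc1)C(=O)N[C@H]1c2ccccc2C[C@H]1O)Cc1ccccc1)C(C)(C)C`: > 10000 nM
Compound 2 `COC(=O)N[C@H](C(=O)NN(CCC[C@@](O)(Cc1ccccc1)C(=O)N[C@H]1c2ccccc2C[C@H]1O)Cc1ccc(Br)cc1)C(C)(C)C`: > 10000 nM

In an ADME assay on MT4 cells (Homo sapiens) for cytotoxicity (on this read-out higher numbers stand for lower toxicity in this test and lower numbers for higher toxicity in this test), compound 1 gives > 10000 nM, which is a limit and not a number. Compound 2 gives > 10000 nM, which is also a limit. Compound 1 therefore has no exact place on the scale, and the whole record consists of the limit of > 10000 nM in this assay, at which 2 of the 2 values shown sit.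

Compound 3 `COC(=O)N[C@H](C(=O)NN(CCC[C@@](O)(Cc1ccccc1)C(=O)N[C@H]1c2ccccc2C[C@H]1O)Cc1ccc(N(C)C)cc1)C(C)(C)C` has not yet been measured. It departs from compound 1 by one change: dimethylamino in place of hydrogen on an aromatic carbon. The benzyl becomes 4-(dimethylamino)benzyl, with the new group on an aromatic carbon, para to a large group.

Among the measured compounds shown here, only one measured step bears on this change, the replacement of hydrogen by bromo on an aromatic carbon: a step that the two limits leave unreadable from compound 1 to compound 2. It gives no size to carry over, but it does show compound 2 still reporting > 10000 nM. In this assay, no step beyond the scatter is therefore expected, in either direction, and another limit is the likely report. The expected step is a step that the limit leaves unreadable from compound 1 to compound 3. The estimate for compound 3 is 15000 nM, with an expected range of 6000 nM to 40000 nM.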

Compound 3, half-maximal cytotoxic concentration: > 10000 nM
Compound 3: a limit, no number; the forecaster's own chance of this, stated with the estimate: 80%; the middle value lies beyond the limit too.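

In this assay compound 3 gives > 10000 nM, which is a limit and not a number. No step from compound 1 or compound 2 to compound 3 can be read, because the record holds only limits: the limit of > 10000 nM in this assay, at which 3 of the 3 values shown sit.

The compounds shown leave open where compound 1, compound 2 and compound 3 actually lie on this scale, and whether they differ at all.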